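This account rests on a few compounds, and the source may have more. Where it says the series, first, only, none or still open, it means among the compounds named here.

Measured so far in a functional assay on A549 cells (Homo sapiens) for cytotoxicity, read by MTT assay, with a stated time of 72 h; on this read-out higher numbers stand for weaker inhibition and lower numbers for stronger inhibition:
compound 1 `COc1cc(/C=C2\CNC/C(=C\c3cc(OC)c(OC)c(OC)c3)C2=O)cc(OC)c1OC` gives 1200 nM
compound 2 `COc1ccc(/C=C2\CN(C)C/C(=C\c3ccc(OC)c(OC)c3)C2=O)cc1OC` gives 1300 nM
compound 3 `CCN1C/C(=C\c2ccc(OC)c(OC)c2)C(=O)/C(=C/c2ccc(OC)c(OC)c2)C1` gives 3600 nM

Compound 1 and compound 2 lie within the scatter of each other, while compound 3 gives a higher number than compound 1, beyond the scatter. The next compound to read is compound 4 `COc1cc(/C=C2\CN(C(=O)CCC(=O)O)C/C(=C\c3cc(OC)c(OC)c(OC)c3)C2=O)cc(OC)c1OC`, which has (2-carboxyethyl)carbonyl in place of hydrogen on an amine nitrogen in a ring on the core of compound 1.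

Going by the values given here, only one measured step bears on this change, and only loosely. Methyl in place of hydrogen on a saturated chain carbon bound to an amine nitrogen in a ring gave a modest shift (a 2.8-fold higher number from compound 2 to compound 3 (0.44 log units; beyond the scatter)), and that change is far smaller than the one here. Among the compounds with values here, no measured compound carries an acyl group on that nitrogen, so the data give no firm direction. The expected step is small (a 1.3-fold higher number from compound 1 to compound 4 (0.10 log units; within the scatter)), with no shift beyond the scatter expected in this assay and a wide margin either way. Compound 4 is estimated at 1500 nM with a range from 400 nM to 5500 nM expected for it.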

Compound 4, half-maximal inhibitory concentration: 17900 nM
The estimate for compound 4 lay 12-fold (1.08 log units) below the measured number, outside the stated range (above it).
By their numbers in this assay, from the lowest: compounds 1 and 2 (each within the scatter of the next); then compound 3; then compound 4.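

In this assay, the amine nitrogen in the six-membered ring of the core of compound 1 proves sensitive to substitution: (2-carboxyethyl)carbonyl in place of hydrogen gives a 15-fold higher number from compound 1 to compound 4 (1.17 log units; beyond the scatter) and places compound 4 last among the four compounds in this assay. Compound 4 is also the only compound shown with an acyl group on this nitrogen, so this is the first direct reading of such a change at this position. No measured evidence available here accounts for the size of this step.

As far as these compounds go, it remains open whether the step follows from the carbonyl on the nitrogen or from the carboxylic acid of the chain. An acetyl group, the methyl ester of the same chain, or a longer chain ending in an amine on this nitrogen would help separate these contributions.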